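From 3-chlorophenyl to 4-(trifluoromethyl)phenyl on compound 2

A few compounds are considered here, and "the series" means these few. Any claim that something is new, unique, unknown or untested is made for them only; others in the source may bear on it.

Of the compounds shown here, two have been tested so far in a functional assay on U-937 cells (Homo sapiens) for inhibition, read by MTT assay, with a stated time of 24 h; on this read-out higher numbers stand for weaker inhibition of growth and lower numbers for stronger inhibition of growth. There, compound 1 `O=C1CC(c2ccc(NC(=O)c3ccc(Cl)c(C(F)(F)F)c3)cc2)=Nc2cnn(Cc3ccccc3)c2N1` gives 60 nM, and compound 2 `COc1ccc(Cn2ncc3c2NC(=O)CC(c2cccc(NC(=O)Nc4cccc(Cl)c4)c2)=N3)cc1` gives 630 nM. Compound 2 thus holds the higher of the two numbers, which means the weaker growth inhibition, and the gap between them lies beyond the usual scatter of repeated measurements.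

Compound 3 `COc1ccc(Cn2ncc3c2NC(=O)CC(c2cccc(NC(=O)Nc4ccc(C(F)(F)F)cc4)c2)=N3)cc1` has not yet been measured. It matches compound 2 except for one group: 4-(trifluoromethyl)phenyl in place of 3-chlorophenyl on an amide-type nitrogen. In words, 4-(trifluoromethyl)phenyl stands in place of 3-chlorophenyl on an amide-type nitrogen. For the measured compounds named here, compound 1 and compound 2 differ in more than one place, so their gap says nothing about this single swap, and no measured pair isolates it.

Starting from compound 2 at 630 nM, no change beyond the scatter is expected in this assay, and either direction remains possible. The expected step is a 1.4-fold lower number from compound 2 to compound 3 (0.15 log units; within the scatter). For compound 3 the estimated value is 450 nM, with an expected range of 130 nM to 1500 nM.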

Compound 3, concentration for 50% growth inhibition: 110 nM
For compound 3 the middle estimate is 4.1-fold (0.61 log units) above the measured one, outside the stated range (below it).
By their numbers in this assay, from the lowest: compounds 1 and 3 (each within the scatter of the next); then compound 2.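

In this assay, the aromatic group on this amide-type nitrogen clearly matters: 4-(trifluoromethyl)phenyl in place of 3-chlorophenyl gives a 5.7-fold lower number from compound 2 to compound 3 (0.76 log units; beyond the scatter), which means stronger inhibition of growth. The gap between the two compounds measured earlier could not be traced to any single part of the structures, whereas here the rest of the molecule stays fixed, so this difference belongs to the swap alone. Nothing available explains why this group gives the stronger growth inhibition.

The swap changes two things at once, the substituent on the ring and its place there, so this single step cannot show which one matters; a 4-chlorophenyl or a 3-(trifluoromethyl)phenyl group on the same nitrogen would separate the two. Going by these compounds, it also remains open how a phenyl ring carrying an amine or a carboxylic acid would behave at this nitrogen, and whether the same swap would give a similar step on a different scaffold, such as that of compound 1.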